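Hydroxy in Place of Carboxypyrrolidinyl: Free Acid Awaits Measurement

The source may hold more compounds than are shown below. What is called first, only, known or untested is meant among the compounds shown, and "the series" means these compounds.

Measured compounds:
compound 1 `CC(C)[C@@H](NC(=O)/C=C/c1ccncc1-c1ccc2ccccc2c1)C(=O)O`, "not determined" (no result reported)
compound 2 `COC(=O)/C=C/c1ccncc1-c1ccc2ccccc2c1`, 40.6 nM
compound 3 `O=C(O)[C@@H]1CCCN1C(=O)/C=C/c1ccncc1-c1ccc2ccccc2c1`, "not determined" (no result reported)

In an assay on a protein complex for inhibition of CDK8/Cyclin C (Homo sapiens), with a stated time of 1 h (on this read-out higher numbers stand for weaker inhibition and lower numbers for stronger inhibition), compound 2 gives 40.6 nM. Compound 3 has no single number in this assay, and compound 1 likewise has no single number, so compound 3 cannot be placed against any measured value. Compound 4 `O=C(O)/C=C/c1ccncc1-c1ccc2ccccc2c1` is the compound still to be measured. It differs from compound 3 by hydroxy in place of 2-carboxypyrrolidin-1-yl on a carbonyl carbon. Among the compounds with values here, no step between measured compounds is available, so the size of the change in this assay cannot be read from the data; any shift from compound 3 is unknown in size and direction, and with no number for compound 3, compound 2 remains the only anchor. Compound 4 is estimated at 60 nM, expected between 15 nM and 300 nM.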

Compound 4, half-maximal inhibitory concentration: 5 nM
Beside the measured number, compound 4's estimate is 12-fold (1.08 log units) above it; the whole stated range lies above it.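

In this assay, hydrogen in place of methyl on an oxygen next to a carbonyl group gives an 8.1-fold lower number from compound 2 to compound 4 (0.91 log units; beyond the scatter), so at this carbonyl the free carboxylic acid inhibits more strongly than the methyl ester. Within the data shown here, this is the first readable change at this position, and it favours the smaller, unsubstituted acid over the ester. Nothing measured here accounts for the difference. Steps involving compound 1 and compound 3 cannot be read, so the effect of amides at this carbonyl stays open. The compounds shown also leave open how a primary amide or a longer ester, such as an ethyl ester, would compare.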